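Chlorophenyl triazole sulfonamides: two positional swaps compared

The source may hold more compounds than are shown below. What is called first, only, known or untested is meant among the compounds shown, and "the series" means these compounds.

Measured compounds:
compound 1, `O=c1[nH]cc(S(=O)(=O)Nc2cccc(-c3cn(-c4ccccc4Cl)nn3)c2)c(=O)[nH]1`: 2730 nM in a functional assay on A549 cells (Homo sapiens) for antiproliferative activity, read by MTT assay, with a stated time of 24 h; on this read-out lower numbers stand for stronger inhibition and higher numbers for weaker inhibition
compound 2, `O=c1[nH]cc(S(=O)(=O)Nc2cccc(-c3cn(-c4cccc(Cl)c4)nn3)c2)c(=O)[nH]1`: 2430 nM in this assay
compound 3, `O=c1[nH]cc(S(=O)(=O)Nc2ccc(-c3cn(-c4ccccc4Cl)nn3)cc2)c(=O)[nH]1`: 2810 nM in this assay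

Compound 2 differs from compound 1 by 3-chlorophenyl in place of 2-chlorophenyl on an aromatic nitrogen; this gave a 1.1-fold lower number from compound 1 to compound 2 (0.05 log units; within the scatter). Compound 3 shares the same 2-chlorophenyl group with compound 1, but the difference between the two cores is not broken down here; their numbers in this assay lie within the usual scatter of each other.

Compound 4, `O=c1[nH]cc(S(=O)(=O)Nc2ccc(-c3cn(-c4cccc(Cl)c4)nn3)cc2)c(=O)[nH]1`, has not been measured. It differs from compound 3 by 3-chlorophenyl in place of 2-chlorophenyl on an aromatic nitrogen, the same change as from compound 1 to compound 2, at the same place. For compound 4 a step of a 1.1-fold lower number from compound 3 to compound 4 (0.04 log units; within the scatter) is expected, resting on the near-flat step a 1.1-fold lower number from compound 1 to compound 2 (0.05 log units; within the scatter). Compound 4 is therefore estimated at 2550 nM, between 1500 nM and 4300 nM.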

Compound 4, half-maximal inhibitory concentration: 2310 nM
Estimate against measurement, compound 4: 1.1-fold (0.04 log units) above; the range from low to high includes it.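

On the second core, 3-chlorophenyl in place of 2-chlorophenyl gives a 1.2-fold lower number from compound 3 to compound 4 (0.09 log units; within the scatter). The change carries over as a near-flat step in this assay, with no difference between the two cores: the same change on two cores in this assay, a 1.1-fold lower number (0.05 log units; within the scatter) from compound 1 to compound 2 and a 1.2-fold lower number (0.09 log units; within the scatter) from compound 3 to compound 4, 1.1-fold (0.03 log units) apart, within the scatter of two such steps. This shows that the swap between these two chlorophenyl groups leaves the number within the scatter on both cores, but it does not show that a change with a larger step would carry over in the same way, or that the same holds on any other core.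

The compounds shown leave open whether a different group on the aromatic nitrogen, such as a phenyl ring bearing an amine or a carboxylic acid, would shift the number beyond the scatter. On these data alone, whether either core would respond differently to such a group also remains open.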